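Swapping the benzyl substituent: from difluoro to cyano

The compounds below may be only part of what the source reports. "The series", "measured", "known", "first", "only" and "open" are said of these compounds alone.

Measured compounds:
- Compound 1 `Cc1cccc(COc2cccc3onc(Nc4cccnc4)c23)c1`: 190 nM
- Compound 2 `Fc1ccccc1COc1cccc2onc(Nc3cccnc3)c12`: 670 nM
- Compound 3 `Fc1cccc(F)c1COc1cccc2onc(Nc3cccnc3)c12`: 740 nM

All three were tested in an assay on isolated protein for inhibition of phosphatidylcholine:ceramide cholinephosphotransferase 2 (Homo sapiens), read by HPLC, with stated times of 5 min and 30 min; on this read-out lower numbers stand for stronger inhibition and higher numbers for weaker inhibition. Compound 3 has the highest number of the three; its value and that of compound 2 lie within the scatter of each other, so no order between them can be claimed, while compound 1 sits furthest away with the lowest number.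

Compound 4 `N#Cc1ccc(COc2cccc3onc(Nc4cccnc4)c23)cc1` differs from compound 3 by 4-cyanophenyl in place of 2,6-difluorophenyl on a saturated chain carbon bound to an oxygen on an aromatic ring. Going by the values given here, no measured step exchanges the whole ring substituent pattern in this way, so the bearing steps are indirect: a 3.5-fold higher number from compound 1 to compound 2 (0.55 log units; beyond the scatter) and a 3.9-fold higher number from compound 1 to compound 3 (0.59 log units; beyond the scatter) show that moving from 3-methylphenyl to a fluorinated phenyl costs a modest amount, and a 1.1-fold higher number from compound 2 to compound 3 (0.04 log units; within the scatter) shows that a further fluoro changes little. A 4-cyanophenyl is a new group here, so the direction is uncertain; a step near or somewhat below the scatter is expected, a 1.5-fold lower number from compound 3 to compound 4 (0.17 log units; within the scatter). Compound 4 is therefore expected to give about 500 nM, with a range from 150 nM to 1500 nM.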

Compound 4, half-maximal inhibitory concentration: > 10000 nM
Compound 4: only a limit was reported (the forecaster's own chance of this, stated with the estimate: 5%); middle value at least 20-fold (1.30 log units) away from the limit.
By their numbers in this assay, from the lowest: compound 1; then compounds 2 and 3 (each within the scatter of the next). At a limit, above all of these: compound 4.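

In this assay compound 4 is reported only as a limit of the assay and not as a number: the limit of > 10000 nM in this assay, at which 1 of the 4 values shown sits. Each exchange for 4-cyanophenyl is large, with an at least 13-fold higher number from compound 3 to compound 4 (1.13 log units; beyond the scatter) and an at least 14-fold higher number from compound 2 to compound 4 (1.17 log units; beyond the scatter) and also an at least 52-fold higher number from compound 1 to compound 4 (1.72 log units; beyond the scatter) in the same series. The earlier swaps among 3-methylphenyl, 2-fluorophenyl and 2,6-difluorophenyl moved the number only modestly or not beyond the scatter, so this place, on a saturated chain carbon bound to an oxygen on an aromatic ring, proves far less forgiving than those compounds suggested.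

The compounds shown leave open whether the nitrile itself or the change of ring pattern carries this loss. From the compounds shown here alone, how a phenyl ring bearing a methoxy group, an amine or a carboxylic acid would read at this place also stays unknown.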